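The source may report more compounds than this note shows. Statements on the series, on what has been measured and on what is new or still open speak of the compounds shown alone.

In a functional assay on MCF7 cells (Homo sapiens) for antiproliferative activity, read by MTT assay, with a stated time of 72 h (a higher number here means a weaker inhibitor, a lower number a stronger inhibitor), two compounds sharing one core have been measured so far. Compound 1 `CCNC(=O)c1cc(Oc2ccc(NC(=O)c3nn(-c4ccccc4C)c(=O)cc3C)cc2)ccn1` gives 44300 nM, and compound 2 `CCNC(=O)c1cc(Oc2ccc(NC(=O)c3nn(-c4cccc(F)c4)c(=O)cc3C)cc2)ccn1` gives 18900 nM, the lower of the two numbers and therefore the stronger result. The unmeasured compound 3 `CCNC(=O)c1cc(Oc2ccc(NC(=O)c3nn(-c4cccc(C(F)(F)F)c4)c(=O)cc3C)cc2)ccn1` keeps all of compound 2 except for one group: it has trifluoromethyl in place of fluoro on an aromatic carbon, meta to a large group (trifluoromethyl in place of fluoro on an aromatic carbon).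

Among the measured compounds shown here, only one measured step offers guidance. Placing 3-fluorophenyl in place of 2-methylphenyl on an aromatic nitrogen gave a 2.3-fold lower number from compound 1 to compound 2 (0.37 log units; beyond the scatter), a modest change. That step alters the same substituent on the aromatic nitrogen, but it does not test trifluoromethyl, so it gives only a rough sense of size and no firm direction. Little or no change beyond the scatter is therefore expected in this assay. The estimated change is a 1.2-fold lower number from compound 2 to compound 3 (0.07 log units; within the scatter). For compound 3, the expected value is 16000 nM, with an estimated range of 6000 nM to 40000 nM.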

Compound 3, half-maximal inhibitory concentration: 40600 nM
Beside the measured number, compound 3's estimate is 2.5-fold (0.40 log units) below it, and the stated range ends below it.
By their numbers in this assay, from the lowest: compound 2; then compounds 3 and 1 (each within the scatter of the next).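

In this assay, replacing fluoro with trifluoromethyl on the same aromatic carbon gave a 2.1-fold higher number from compound 2 to compound 3 (0.33 log units; beyond the scatter), so the lower number seen with the 3-fluorophenyl group does not carry over to every fluorine-bearing group placed there. Compared with the 2-methylphenyl group of compound 1, the 3-(trifluoromethyl)phenyl group gave a 1.1-fold lower number from compound 1 to compound 3 (0.04 log units; within the scatter), which means that this change to the group on the aromatic nitrogen makes no clear difference. Among the three compounds, only compound 2 stands clear of the other two, so the substituent on this ring can change the result, but the effect depends on the particular group. Nothing available explains why fluoro and trifluoromethyl differ at this position.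

The compounds shown leave open how groups other than fluoro and trifluoromethyl behave on this carbon, such as an amine, a carboxylic acid, a nitrile or a longer alkyl chain. They also leave open whether a plain phenyl ring with only hydrogen at this position would give a number closer to that of compound 2 or to that of compound 3.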